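Shortening the Amine Side Chain of a Sulfonamide Piperazine

A few compounds are considered here, and "the series" means these few. Any claim that something is new, unique, unknown or untested is made for them only; others in the source may bear on it.

Measured compounds:
Compound 1, `COc1cc(C)c(S(=O)(=O)N(C)CCOCC(=O)N2CCN(CCCN(C)C)CC2)c(C)c1` — 5.8 nM
Compound 2, `COc1cc(C)c(S(=O)(=O)N(C)CCOCC(=O)N2CCC(C3CCN(C)CC3)CC2)c(C)c1` — 0.7 nM

In an assay on HEK293 cells for displacement of a labelled ligand from B1 bradykinin receptor (Homo sapiens), read by scintillation counting (a higher number here means a weaker inhibitor, a lower number a stronger inhibitor), compound 1 gives 5.8 nM, the higher of the two numbers; compound 2 gives 0.7 nM, a gap beyond the scatter. Compound 3, `COc1cc(C)c(S(=O)(=O)N(C)CCOCC(=O)N2CCN(CCN(C)C)CC2)c(C)c1`, differs from compound 1 by one change: dimethylamino in place of (dimethylamino)methyl on a saturated chain carbon, two bonds along the chain from an amine nitrogen in a ring. Going by the values given here, no measured pair shows this change, so its effect is unknown. The expected step of a 1.4-fold higher number from compound 1 to compound 3 (0.14 log units; within the scatter) is small and, if anything, toward a weaker inhibitor. Compound 3 is estimated at 8 nM, with a range from 2 nM to 30 nM.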

Compound 3, inhibition constant: 106 nM
Compound 3: the middle estimate sits 13-fold (1.12 log units) below what was measured, and the stated range ends below it.
By their numbers in this assay, from the lowest: compound 2; then compound 1; then compound 3.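

At this position, going from 3-(dimethylamino)propyl to 2-(dimethylamino)ethyl gives an 18-fold higher number from compound 1 to compound 3 (1.26 log units; beyond the scatter) in this assay and so makes a much weaker inhibitor. The length of this chain therefore matters greatly, even though the change in heavy atoms is small. Nothing measured here explains the loss. On these data alone, what remains open is how a longer chain, such as 4-(dimethylamino)butyl, would compare with 3-(dimethylamino)propyl. As far as these compounds go, it is also open whether a different amine, such as pyrrolidine in place of dimethylamino, would tolerate the shorter chain.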